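Series notes: trimethoxyphenyl variant in the FAM20C inhibition assay

A few compounds are considered here, and "the series" means these few. Any claim that something is new, unique, unknown or untested is made for them only; others in the source may bear on it.

Measured so far:
Compound 1 `COc1ccc(Nc2ccnc(Nc3ccc(NS(=O)(=O)c4ccc(C(F)(F)F)cc4)cc3)n2)cc1`: 18%
Compound 2 `COc1ccc(Nc2ccnc(Nc3ccc(NS(=O)(=O)c4ccc(C)cc4)cc3)n2)cc1`: 28%

In an assay on isolated protein for inhibition of extracellular serine/threonine protein kinase FAM20C (Homo sapiens), read by malachite green, tested at 10 uM, in the presence of a further agent that is not named here (on this read-out higher numbers stand for more inhibition at the one concentration tested (going by the name of the read-out) and lower numbers for less inhibition), compound 1 gives 18% and compound 2 gives 28%. Among the compounds with values here, the single measured step, a number 10 percentage points higher from compound 1 to compound 2 (within the scatter), lies within the scatter. On the numbers shown compound 2 holds the higher of the two values, with compound 1 nearest, but the gap is within the scatter, so no order between the two compounds can be read from it.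

Compound 3 `COc1cc(Nc2ccnc(Nc3ccc(NS(=O)(=O)c4ccc(C)cc4)cc3)n2)cc(OC)c1OC` is not yet measured. The change from compound 2: 3,4,5-trimethoxyphenyl in place of 4-methoxyphenyl on a nitrogen on an aromatic ring. Within the data shown here, the only measured step concerns methyl in place of trifluoromethyl on an aromatic carbon, a different place from the nitrogen on an aromatic ring altered here, so no measured step bears on this change. The step of no change at the digits printed from compound 2 to compound 3 (within the scatter) is therefore expected to stay within the scatter. Compound 3 is estimated to give 28% in this assay, with a range of 10% to 46%.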

Compound 3, a percentage reported as inhibition, at one concentration (the size of the read-out at that concentration, not a potency): 28%
For compound 3 middle estimate and measured number coincide at the digits printed; the range from low to high includes it.
By their numbers in this assay, from the lowest: compounds 1, 2 and 3 (each within the scatter of the next).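

In this assay, within the data shown here, the step of no change at the digits printed from compound 2 to compound 3 (within the scatter) is the first reading at the nitrogen on an aromatic ring, where 3,4,5-trimethoxyphenyl stands in place of 4-methoxyphenyl. For this one pair, the larger group, with more heavy atoms and more hydrogen-bond acceptors, leaves the read-out within the scatter, so the added methoxy groups show no measurable gain or loss at the one concentration tested. Nothing independent of these numbers bears on this result.

Going by these compounds, whether an amine or a carboxylic acid on this aromatic ring would move the number beyond the scatter remains open. Also open, on these data alone, is whether 3,4,5-trimethoxyphenyl would read the same with trifluoromethyl in place of methyl, and a single-concentration percentage says nothing about potency.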